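A few compounds are considered here, and "the series" means these few. Any claim that something is new, unique, unknown or untested is made for them only; others in the source may bear on it.

Working notes on the series.

In a functional assay on PC-3 cells (Homo sapiens) for cytotoxicity, read by MTT assay, with a stated time of 48 h (a lower number here means a stronger inhibitor, a higher number a weaker inhibitor), three compounds have numbers. Compound 1 `O=C(NC1CCCCC1)c1cc(Oc2cccc(NC(=S)Nc3cccc(C(F)(F)F)c3)c2)ccn1` gives 16800 nM. Compound 2 `O=C(NCc1ccccc1)c1cc(Oc2cccc(NC(=S)Nc3cccc(C(F)(F)F)c3)c2)ccn1` gives 11000 nM. Within the data shown here, the only single-place step between measured compounds is a 1.5-fold lower number from compound 1 to compound 2 (0.18 log units; within the scatter). Compound 3 `O=C(c1cc(Oc2cccc(NC(=S)Nc3ccc(Cl)c(C(F)(F)F)c3)c2)ccn1)N1CCCC1` gives 12100 nM, the second highest of the three numbers; it stands nearest to compound 2 and furthest from compound 1, both gaps within the scatter, so no order among the three can be claimed. Among the measured compounds shown here, compound 3 differs from compound 1 and from compound 2 in two places at once, so those pairs yield no single-place step.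

Compound 4 `O=C(c1cc(Oc2cccc(NC(=S)Nc3ccc(OC(F)(F)F)cc3)c2)ccn1)N1CCCC1` is the next to be measured. It differs from compound 3 in one place: 4-(trifluoromethoxy)phenyl in place of 4-chloro-3-(trifluoromethyl)phenyl on an amide-type nitrogen. For the measured compounds named here, no measured step alters the aryl on the thiocarbonyl side; the one step with a number, a 1.5-fold lower number from compound 1 to compound 2 (0.18 log units; within the scatter), changes the group on the other amide-type nitrogen and leaves the part now altered untouched. Going by the values given here, nothing in the numbers so far points to a step beyond the scatter in this assay in either direction, and the expected step is a 1.0-fold lower number from compound 3 to compound 4 (0.00 log units; within the scatter). Compound 4 is estimated at 12000 nM, with a range from 5000 nM to 30000 nM.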

Compound 4, half-maximal inhibitory concentration: 34100 nM
Beside the measured number, compound 4's estimate is 2.8-fold (0.45 log units) below it; the measured number lies above the stated range.
By their numbers in this assay, from the lowest: compounds 2, 3 and 1 (each within the scatter of the next); then compound 4.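

Among these compounds, this is the first step beyond the scatter and the first at the amide-type nitrogen whose other neighbour is the thiocarbonyl carbon: in this assay, the number rises by a 2.8-fold higher number from compound 3 to compound 4 (0.45 log units; beyond the scatter) when 4-(trifluoromethoxy)phenyl replaces 4-chloro-3-(trifluoromethyl)phenyl. Among the compounds shown here, the response at this position is therefore not flat, and the only measured change in the group on the other amide-type nitrogen, the swap of cyclohexyl for benzyl, stays within the scatter. The heavy-atom count is the same in the two groups, so the step comes with a change in the atoms and their arrangement, not in that count, and nothing at hand bears on the reason for it.

The single swap changes the chlorine and the trifluoromethyl group together, so the compounds shown cannot assign the step to either one; a phenyl bearing chlorine alone, or a methoxy group in place of the trifluoromethoxy group, would help separate these parts. Also open, as far as these compounds go, is whether the same change gives a step of similar size with the cyclohexyl or benzyl groups on the other amide-type nitrogen.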